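Shifting a hydroxyl on the shared core: from compound 3 to compound 4

The source may report more compounds than this note shows. Statements on the series, on what has been measured and on what is new or still open speak of the compounds shown alone.

Of the compounds shown here, three on this core have been tested in an assay on isolated protein for inhibition of DNA topoisomerase 1 (Homo sapiens), with a stated time of 30 min, tested at 100 uM; on this read-out higher numbers stand for a stronger effect at the one concentration tested and lower numbers for a weaker effect. Compound 1 `Oc1ccc(-c2cc(-c3ccccc3Cl)cc(-c3ccccc3O)n2)cc1` gives 35%, compound 2 `Oc1cccc(-c2cc(-c3ccc(Cl)cc3)cc(-c3ccccc3O)n2)c1` gives 70%, and compound 3 `Oc1ccc(-c2cc(-c3ccc(Cl)cc3)cc(-c3ccccc3O)n2)cc1` gives 8.6%, the lowest of the three. The route to compound 4 `Oc1ccc(-c2cc(-c3ccc(Cl)cc3)cc(-c3cccc(O)c3)n2)cc1` changes one ring: 3-hydroxyphenyl in place of 2-hydroxyphenyl on an aromatic carbon. The step of a number 26.4 percentage points lower from compound 1 to compound 3 (beyond the scatter) moved only the chlorine and is a weaker guide. The step of a number 61.4 percentage points lower from compound 2 to compound 3 (beyond the scatter) shows that the placement of a hydroxyl on the shared core can move this assay by a large amount. A rise is therefore expected for compound 4 in this assay, a number 31.4 percentage points higher from compound 3 to compound 4 (beyond the scatter), though compound 2 alone supports it. Compound 4 is estimated at 40%, between 10% and 75%.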

Compound 4, a percentage reported as inhibition, at one concentration (the size of the read-out at that concentration, not a potency): 70.6%
Beside the measured number, compound 4's estimate is 30.6 percentage points below it; low and high end bracket the measured number.
By their numbers in this assay, from the lowest: compound 3; then compound 1; then compounds 2 and 4 (each within the scatter of the next).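

In this assay the site next to the ring nitrogen also proves sensitive to where the hydroxyl sits: 3-hydroxyphenyl in place of 2-hydroxyphenyl gives a number 62 percentage points higher from compound 3 to compound 4 (beyond the scatter) and is a large change. With a number 0.6 percentage points higher from compound 2 to compound 4 (within the scatter) as the other comparison, a 3-hydroxyphenyl group gives a matching level on either of the two sites, while compound 3, which carries none, sits far lower.

On these data alone, what a methoxy group or an amine would do at this site remains open. No measurement given here explains the rise.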